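The source may report more compounds than this note shows. Statements on the series, on what has been measured and on what is new or still open speak of the compounds shown alone.

In an in vitro functional assay on cells for agonist activity at Bombesin receptor subtype-3 (Homo sapiens), read by luminescence and calcium flux (a higher number here means that more compound is needed for the effect, a lower number that less compound is needed), three compounds have been measured so far:
compound 1 `O=C(O)c1ccccc1-c1ccc(CCc2ncc(CCC3CCCCC3)[nH]2)cc1` gives 642 nM;
compound 2 `O=C(O)c1ccccc1-c1ccc(CCc2ncc(Cc3cccc(Cl)c3)[nH]2)cc1` gives 825 nM;
compound 3 `O=C(O)c1ccccc1-c1ccc(CCc2ncc(Cc3ccc(Cl)cc3)[nH]2)cc1` gives 2290 nM.

Compound 1 has the lowest number of the three. Compound 2 sits nearest to it, with a 1.3-fold higher number from compound 1 to compound 2 (0.11 log units; within the scatter), a gap within the usual scatter of this kind of measurement; compound 3 lies furthest away, with a 3.6-fold higher number from compound 1 to compound 3 (0.55 log units; beyond the scatter). Between the two chlorophenyl compounds the step is a 2.8-fold higher number from compound 2 to compound 3 (0.44 log units; beyond the scatter).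

Compound 4 `Cc1ccccc1Cc1cnc(CCc2ccc(-c3ccccc3C(=O)O)cc2)[nH]1` has not yet been measured. It differs from compound 1 in one place: 2-methylphenyl in place of cyclohexylmethyl on a saturated chain carbon bound to an aromatic carbon. For the measured compounds named here, two measured steps bear on this change, both of which replace the same cyclohexylmethyl with a chlorine-bearing aromatic ring: a 1.3-fold higher number from compound 1 to compound 2 (0.11 log units; within the scatter) and a 3.6-fold higher number from compound 1 to compound 3 (0.55 log units; beyond the scatter). Neither of these moves lowered the number; one stayed within the scatter and the other rose modestly. As far as these compounds go, a 2-methylphenyl group has not been tried here, so how a methyl compares with a chlorine on the aromatic ring is unknown. On that footing a small rise in the number, or no change beyond the scatter, is expected for compound 4, with the step estimated as a 1.9-fold higher number from compound 1 to compound 4 (0.27 log units; within the scatter). Compound 4 is therefore estimated at 1200 nM, with a range from 500 nM to 3500 nM.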

Compound 4, half-maximal effective concentration: 127 nM
Estimate against measurement, compound 4: 9.4-fold (0.98 log units) above, and the stated range ends above it.
By their numbers in this assay, from the lowest: compound 4; then compounds 1 and 2 (each within the scatter of the next); then compound 3.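

In this assay the chlorine-bearing rings had shown no gain over cyclohexylmethyl, but 2-methylphenyl gives a 5.1-fold lower number from compound 1 to compound 4 (0.70 log units; beyond the scatter) with the same count of heavy atoms, so an aromatic ring on this saturated chain carbon bound to an aromatic carbon can lower the number. Changes among the aromatic groups alone also move the number widely, with a 6.5-fold lower number from compound 2 to compound 4 (0.81 log units; beyond the scatter) on going from 3-chlorophenyl to 2-methylphenyl and an 18-fold lower number from compound 3 to compound 4 (1.26 log units; beyond the scatter) on going from 4-chlorophenyl to 2-methylphenyl, the last of these a large step, so having an aromatic ring here does not by itself set the result; what the ring carries and where it carries it matter as well. Nothing available here explains why this group gives the lowest number of the four.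

The steps from the chlorophenyl compounds change both the group on the ring and its place, so the effect of each remains unseparated; a chlorine standing where the methyl of 2-methylphenyl stands would divide the two. A plain phenyl ring with neither methyl nor chlorine would show whether the methyl itself contributes to the lower number or the ring alone accounts for it.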